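The source may hold more compounds than are shown below. What is called first, only, known or untested is meant among the compounds shown, and "the series" means these compounds.

Values in an assay for inhibition of histone acetyltransferase KAT2B (Homo sapiens), read by fluorescence (a higher number here means a weaker inhibitor, a lower number a stronger inhibitor), for the three measured compounds:

compound 1, `O=c1c2cccnc2sn1Cc1ccccc1`: 23000 nM
compound 2, `O=c1c2cccnc2sn1-c1ccc(Br)cc1`: 4430 nM
compound 3, `Cc1cnc2sn(-c3ccc([N+](=O)[O-])cc3)c(=O)c2c1`: 15300 nM

Compound 1 has the highest number of the three. Its nearest neighbour is compound 3, whose number is lower by an amount that stays within the scatter, so no order between compound 1 and compound 3 can be read from these two values. Compound 2 stands furthest away, with a number lower than that of compound 1 by a margin beyond the scatter; compound 2 is thus the stronger of that pair in this assay. Going by the values given here, no two of the measured compounds differ in a single place, so no isolated step is available as a guide.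

Compound 4, `O=c1c2cccnc2sn1Cc1ccc(F)cc1`, is the next compound to be measured. It differs from compound 1 by fluoro in place of hydrogen on an aromatic carbon. A change of this kind, with a single heavy atom entering and no ring, donor, acceptor or charge added, is expected to move the number in this assay by little, with no step beyond the scatter in either direction. The expected step of a 1.3-fold lower number from compound 1 to compound 4 (0.11 log units; within the scatter) is therefore small. Compound 4 is estimated at 18000 nM, within a range from 7000 nM to 45000 nM.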

Compound 4, half-maximal inhibitory concentration: 86300 nM
Beside the measured number, compound 4's estimate is 4.8-fold (0.68 log units) below it; measured number above the stated range.
By their numbers in this assay, from the lowest: compound 2; then compounds 3 and 1 (each within the scatter of the next); then compound 4.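

In this assay, fluoro in place of hydrogen on an aromatic carbon, para to a large group, gives a 3.8-fold higher number from compound 1 to compound 4 (0.57 log units; beyond the scatter), and this step lies beyond the scatter. Going by these compounds alone, this is the first comparison that isolates a single place, and it shows that this place on the six-membered aromatic ring of carbon only is not indifferent to a change of one heavy atom: the entry of fluoro, with no ring, donor, acceptor or charge added, makes compound 4 the weaker inhibitor of the pair. No measurement of any property or of binding accompanies this step, so nothing here accounts for its direction or size.

As far as these compounds go, it remains open whether this weakening is particular to fluoro or extends to other groups at the same place, such as chloro, methoxy, an amine or a carboxylic acid. Also open, from the compounds shown here alone, is whether the same change would give a step of similar direction and size on the core of compound 1 with a longer chain leading to the aromatic ring.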